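Working notes: from compound 3 to compound 4

A few compounds are considered here, and "the series" means these few. Any claim that something is new, unique, unknown or untested is made for them only; others in the source may bear on it.

- compound 1 `O=C1/C(=C/c2ccccc2F)CN(Cc2cn(Cc3cccc(Cl)c3)nn2)C/C1=C\c1ccccc1F` gives 4300 nM
- compound 2 `O=C1/C(=C/c2ccccc2F)CN(C(=S)SCc2cn(Cc3ccccc3Cl)nn2)C/C1=C\c1ccccc1F` gives 46300 nM
- compound 3 `Cc1ccc(/C=C2\CN(C(=S)SCc3cn(Cc4ccc(F)cc4)nn3)C/C(=C\c3ccc(C)cc3)C2=O)cc1` gives 38800 nM

In a functional assay on DU-145 cells (Homo sapiens) for cytotoxicity, read by MTT assay, with a stated time of 24 h (on this read-out lower numbers stand for stronger inhibition and higher numbers for weaker inhibition), compound 3 gives 38800 nM and lies within the scatter of compound 2 (46300 nM), while compound 1 (4300 nM) sits lower than both by more than the scatter.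

Compound 4 `Cc1ccc(/C=C2\CN(C(=S)SCc3cn(Cc4ccccc4F)nn3)C/C(=C\c3ccc(C)cc3)C2=O)cc1` differs from compound 3 by one exchange (2-fluorophenyl in place of 4-fluorophenyl on a saturated chain carbon bound to an aromatic nitrogen), with 2-fluorophenyl in place of 4-fluorophenyl on a saturated chain carbon bound to an aromatic nitrogen. Among the measured compounds shown here, no measured pair isolates this change, so the data offer no direct precedent. Compound 2 (46300 nM) and compound 3 (38800 nM) differ in more than one place yet stay within the scatter of each other, so no step beyond the scatter is expected in this assay for this exchange. The expected step of a 1.0-fold lower number from compound 3 to compound 4 (0.01 log units; within the scatter) is therefore small and within the scatter. For compound 4 the estimated value is 38000 nM, with an expected range from 15000 nM to 85000 nM in this read-out.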

Compound 4, half-maximal inhibitory concentration: 80000 nM
Estimate against measurement, compound 4: 2.1-fold (0.32 log units) below; low and high end bracket the measured number.
By their numbers in this assay, from the lowest: compound 1; then compounds 3, 2 and 4 (each within the scatter of the next, the first and the last beyond it).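

In this assay, among the compounds shown here, the exchange of 4-fluorophenyl for 2-fluorophenyl on a saturated chain carbon bound to an aromatic nitrogen gives the first step that isolates a single place: a 2.1-fold higher number from compound 3 to compound 4 (0.31 log units; beyond the scatter). The groups that leave and enter have the same atoms and the same counts, so this position responds to how those atoms are joined, even though the higher number still reflects only a modest loss of inhibition. Nothing measured here gives a reason for this step.

A single pair cannot show whether the step holds when the other groups on the shared core differ. As far as these compounds go, how this position responds to an unsubstituted benzyl, an amine or a carboxylic acid in place of the fluorophenyl also remains open.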